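Ketone-side aryl swap: compound 1 to compound 4

A few compounds are considered here, and "the series" means these few. Any claim that something is new, unique, unknown or untested is made for them only; others in the source may bear on it.

Among the measured compounds shown here, compound 1 `C#CCOc1ccc(/C=C/C(=O)c2cccc(OC)c2)cc1OC` gives the lowest number of the three measured so far in a functional assay on U-87MG ATCC cells for cytotoxicity against U-87 MG (Homo sapiens), with a stated time of 72 h (a lower number here means a stronger inhibitor, a higher number a weaker inhibitor), at 1460 nM. Compound 3 `C#CCOc1ccc(/C=C/C(=O)c2ccc(OC)c(OC)c2)cc1OC`, at 2860 nM, sits nearest, and the step of a 2.0-fold higher number from compound 1 to compound 3 (0.29 log units; within the scatter) lies within the scatter. For the measured compounds named here, compound 2 `C=CCOc1ccc(C=O)cc1OC`, at 7500 nM, sits furthest from compound 1, beyond the scatter; no single-point step connects compound 2 to compound 1, so its value is noted without further reading.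

Compound 4 `C#CCOc1ccc(/C=C/C(=O)c2ccccc2C)cc1OC` differs from compound 1 by 2-methylphenyl in place of 3-methoxyphenyl on a carbonyl carbon. Going by the values given here, the only measured step touching the same ring is a 2.0-fold higher number from compound 1 to compound 3 (0.29 log units; within the scatter), a change within the scatter. That single step gives no sign that substitution on the carbonyl-bearing ring moves this assay beyond the scatter, so for the present change the expected step is a 1.4-fold higher number from compound 1 to compound 4 (0.14 log units; within the scatter), with no direction beyond the scatter. Among the compounds with values here, compound 4 is therefore estimated at 2000 nM, with a range from 700 nM to 6000 nM; the range is kept wide since only one prior step bears on this ring and the present change is of a different kind.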

Compound 4, half-maximal inhibitory concentration: 2100 nM
Estimate against measurement, compound 4: 1.1-fold (0.02 log units) below, within the range that was stated.
By their numbers in this assay, from the lowest: compounds 1, 4 and 3 (each within the scatter of the next); then compound 2.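

In this assay, 2-methylphenyl in place of 3-methoxyphenyl on a carbonyl carbon gives a 1.4-fold higher number from compound 1 to compound 4 (0.16 log units; within the scatter). The earlier step on this ring only added a methoxy group, whereas this one swaps the whole aryl group for one without oxygen, and the number still stays within the scatter, so in this pair the methoxy group of compound 1 is not needed to hold the value. No measurement on hand offers an explanation for this result.

This single step changes both the kind of substituent and its place on the ring, so 3-methylphenyl or 2-methoxyphenyl would be needed to separate the two. Going by these compounds, whether any group on this carbonyl carbon moves the number beyond the scatter remains open, for instance an aryl ring carrying an amine or a carboxylic acid.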